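A few compounds are considered here, and "the series" means these few. Any claim that something is new, unique, unknown or untested is made for them only; others in the source may bear on it.

Working notes on the series. In a functional assay (strain BALB/C) for antagonist activity at adenosine receptor A1 (Mus musculus), with a stated time of 1 h, tested at 1 uM (on this read-out higher numbers stand for weaker inhibition and lower numbers for stronger inhibition), compound 1 `CCCC1CCC(CCC)(n2c(=O)[nH]c3nc[nH]c3c2=O)C1` gives 5 nM. Compound 2 `Cn1c(-c2ccc(F)cc2)nc2c(NC3CCCC3)ncnc21` gives 43 nM in this assay, and compound 3 `Cn1c(-c2ccc(O)cc2)nc2c(NC3CCCC3)ncnc21` gives 66 nM. Among these three numbers compound 3 sits within the scatter of compound 2, as the step of a 1.5-fold higher number from compound 2 to compound 3 (0.19 log units; within the scatter) shows, while the gap between compound 3 and compound 1 is beyond the scatter.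

Compound 4 `Cc1ccc(-c2nc3c(NC4CCCC4)ncnc3n2C)cc1` has not yet been measured in this assay. It differs from compound 3 by methyl in place of hydroxy on an aromatic carbon. Within the data shown here, the only measured step touching this part of the molecule is a 1.5-fold higher number from compound 2 to compound 3 (0.19 log units; within the scatter), an exchange of one substituent for another on an aromatic carbon that stayed within the scatter; no measured step covers hydroxy to methyl directly, so the expectation rests on that single comparison. On that basis the expected step of a 1.3-fold lower number from compound 3 to compound 4 (0.12 log units; within the scatter) is none beyond the scatter. Compound 4 is therefore estimated at 50 nM, with a range from 18 nM to 140 nM.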

Compound 4, antagonist equilibrium constant: 177 nM
Compound 4: the middle estimate sits 3.5-fold (0.55 log units) below what was measured; the whole stated range lies below it.
By their numbers in this assay, from the lowest: compound 1; then compounds 2 and 3 (each within the scatter of the next); then compound 4.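

At this aromatic carbon, para to a large group, the exchange of one substituent for another can register in this assay beyond the scatter: the changes are modest, with a 2.7-fold higher number from compound 3 to compound 4 (0.43 log units; beyond the scatter) and with a 4.1-fold higher number from compound 2 to compound 4 (0.61 log units; beyond the scatter). Hydroxy and fluoro stay within the scatter of each other (a 1.5-fold higher number from compound 2 to compound 3 (0.19 log units; within the scatter)), so among these three groups methyl alone stands apart, on the side of weaker inhibition. No measurement among those given accounts for this separation.

As far as these compounds go, the position has so far carried only fluoro, hydroxy and methyl, so it remains open whether an ethyl group, a methoxy group or an amine would follow methyl or stay with the other two. Compound 1 differs from the others in more than one place and says nothing about this position.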